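Pyridin-2-yl in place of carboxy: expectation for compound 3

A few compounds are considered here, and "the series" means these few. Any claim that something is new, unique, unknown or untested is made for them only; others in the source may bear on it.

Two measured members share the core. Compound 1 `CCCCN(c1nc2c(C(=O)N(C)C)cccc2o1)[C@H](C)c1ccc(-c2ccccc2-c2nnn[nH]2)cc1` gives 13 nM in a functional assay on CAL1 cells for inhibition of chemerin-like receptor 1 (Homo sapiens), with a stated time of 45 min; a lower number here means a stronger inhibitor, a higher number a weaker inhibitor. Compound 2 `CCCCN(c1nc2c(C(=O)O)cccc2o1)[C@H](C)c1ccc(-c2ccccc2-c2nnn[nH]2)cc1` gives 17 nM in the same assay. Among the compounds with values here, the only measured step, a 1.3-fold higher number from compound 1 to compound 2 (0.12 log units; within the scatter), shows that exchanging the group on the carbonyl carbon leaves the readout essentially unchanged; compound 2 thus stands within the scatter of compound 1, so no order between the two can be drawn from these numbers.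

Compound 3 `CCCCN(c1nc2c(-c3ccccn3)cccc2o1)[C@H](C)c1ccc(-c2ccccc2-c2nnn[nH]2)cc1` is not yet measured. It differs from compound 2 in this way: pyridin-2-yl in place of carboxy on an aromatic carbon. The step of a 1.3-fold higher number from compound 1 to compound 2 (0.12 log units; within the scatter) is the only one bearing on this position, and it was within the scatter, so the position tolerates at least one exchange of a carboxy-type substituent. The new change is larger in size and of a different kind, with an aromatic ring entering and the hydrogen-bond donor leaving, so the measured step is only a loose guide. The expectation is a step of a 1.8-fold higher number from compound 2 to compound 3 (0.25 log units; within the scatter), a modest weakening at most, with wide uncertainty. Compound 3 is estimated at 30 nM, within a range of 8 nM to 120 nM.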

Compound 3, half-maximal inhibitory concentration: 110 nM
The estimate for compound 3 lay 3.7-fold (0.56 log units) below the measured number; measured number inside the range.
By their numbers in this assay, from the lowest: compounds 1 and 2 (each within the scatter of the next); then compound 3.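

In this assay, the aromatic carbon ortho to a fused ring proves sensitive to what it carries: pyridin-2-yl in place of carboxy gives a 6.5-fold higher number from compound 2 to compound 3 (0.81 log units; beyond the scatter), and pyridin-2-yl in place of dimethylcarbamoyl gives an 8.5-fold higher number from compound 1 to compound 3 (0.93 log units; beyond the scatter), both beyond the scatter. The earlier step, a 1.3-fold higher number from compound 1 to compound 2 (0.12 log units; within the scatter), covered only an exchange on a carbonyl carbon, so the tolerance it suggested extends to those two carbonyl groups and, on this evidence, not to a directly attached aromatic ring. Nothing available accounts for the size of the two new steps.

Compound 3 differs from compound 1 and compound 2 both in lacking a carbonyl at this position and in carrying a ring there, so these numbers cannot separate the two changes. A phenyl or pyridin-3-yl group would test whether the ring itself or its nitrogen placement matters, while an acetyl group or a methyl ester would test how far a small carbonyl group alone holds the readout.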